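The source may report more compounds than this note shows. Statements on the series, on what has been measured and on what is new or still open speak of the compounds shown alone.

Compound 1 `O=C(Nc1ccc(Cl)c(C(F)(F)F)c1)N[C@H]1CCN(c2ccc3nncn3n2)C1`: 1000 nM
Compound 2 `O=C(Nc1ccc(Cl)c(C(F)(F)F)c1)N[C@@H]1CCN(c2ccc3nncn3n2)C1`: 1000 nM

In a physicochemical assay for solubility, measured as kinetic solubility (on this read-out higher numbers stand for higher solubility and lower numbers for lower solubility), compound 1 gives 1000 nM, level with compound 2 at 1000 nM. Among the compounds with values here, the one measured step shows no change at the digits printed from compound 1 to compound 2 (within the scatter), and what separates the pair is the fact that compounds 1 and 2 differ only in the configuration as drawn.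

Compound 3 `Nc1nccc(N2CC[C@H](NC(=O)Nc3ccc(Cl)c(C(F)(F)F)c3)C2)n1` keeps the rest of compound 1 and changes one group: a group of 7 heavy atoms (4 carbon, 3 nitrogen; one six-membered aromatic ring with 2 hetero atoms) in place of a group of 9 heavy atoms (5 carbon, 4 nitrogen; one five-membered aromatic ring with 3 hetero atoms, one six-membered aromatic ring with 2 hetero atoms), on an amine nitrogen in a ring. The incoming 2-aminopyrimidin-4-yl group stands on the same amine nitrogen in a ring.

The measured step replaces no group, so it bears on this change only weakly. Within the data shown here, no measured compound yet shows what such a swap does. With so little to go on, no shift beyond the scatter is expected, though the uncertainty is wide. The expected change is no change at the digits printed from compound 1 to compound 3 (within the scatter). For compound 3 the estimated value is 1000 nM, with an expected range from 300 nM to 5000 nM.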

Compound 3, solubility: 30300 nM
Compound 3: middle estimate off by 30-fold (1.48 log units), on the low side; measured number above the stated range.
By their numbers in this assay, from the lowest: compounds 1 and 2 (each within the scatter of the next); then compound 3.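

In this assay, the group on the amine nitrogen in the ring matters far more than the drawn configuration at the saturated ring carbon. Exchanging the two-ring group for 2-aminopyrimidin-4-yl gives a 30-fold higher number from compound 1 to compound 3 (1.48 log units; beyond the scatter), whereas inverting the stereocentre gives no change at the digits printed from compound 1 to compound 2 (within the scatter). The incoming group has one aromatic ring instead of two and one hydrogen-bond donor instead of none, but nothing measured here says which of these differences, if either, accounts for the shift.

This single swap alters the ring count and the donor count together, so their contributions cannot be separated. As far as these compounds go, it remains open whether a plain pyrimidin-4-yl group without the amine would hold the higher number, and whether inverting the stereocentre of compound 3 would leave its number unchanged.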